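The source may hold more compounds than are shown below. What is called first, only, known or untested is meant among the compounds shown, and "the series" means these compounds.

Measured in a functional assay on SK-HEP1 cells (Homo sapiens) for inhibition, read by MTT assay, with a stated time of 72 h; a lower number here means a stronger inhibitor, a higher number a weaker inhibitor:
Compound 1 `Nc1ncnc2c1c(-c1cnc3[nH]ccc3c1)nn2CCCCCCCCCC(=O)NO`: 23500 nM
Compound 2 `Nc1nc2cc(-c3nn(CCCCC(=O)NO)c4ncnc(N)c34)ccc2o1`: 6400 nM

Compound 2 holds the lower of the two numbers, which makes it the stronger inhibitor of this pair, and the gap to compound 1 lies beyond the scatter. Compound 3 `Nc1nc2cc(-c3nn(CCCCCCCCC(=O)NO)c4ncnc(N)c34)ccc2o1` keeps the rest of compound 2 but carries 4-(hydroxycarbamoyl)butyl in place of hydroxycarbamoyl on a saturated chain carbon, four bonds along the chain from an aromatic nitrogen.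

Within the data shown here, no pair of measured compounds differs in just one place, so the size of this step in this assay has no direct precedent. A modest move toward a lower number is expected, though a step within the scatter would be no surprise. The estimated change is a 2.1-fold lower number from compound 2 to compound 3 (0.33 log units; beyond the scatter). For compound 3 the expected value is 3000 nM, with an estimated range from 500 nM to 15000 nM.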

Compound 3, half-maximal inhibitory concentration: > 100000 nM
Compound 3: no number, only a limit; the forecaster's own chance of this, stated with the estimate: 5%; at least 33-fold (1.52 log units) between middle value and limit.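

On this saturated chain, four bonds along from an aromatic nitrogen, 4-(hydroxycarbamoyl)butyl in place of hydroxycarbamoyl is far from a neutral change in this assay: it gives an at least 15-fold higher number from compound 2 to compound 3 (1.19 log units; beyond the scatter), a large loss of strength. Among these compounds, this is the first single change that can be read, and it shows that keeping the same hydroxycarbamoyl end group does not keep the activity once the chain carrying it grows longer. The value for compound 3 is a limit of the assay and not a number, so the true size of the step stays unknown: the limit of > 100000 nM in this assay, at which 1 of the 3 values shown sits.

On these data alone, whether a chain of intermediate length ending in hydroxycarbamoyl would hold the strength of compound 2 remains open. So does the effect of a carboxylic acid in place of hydroxycarbamoyl at the end of the chain.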